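A methoxy group added to the phenoxy ring of compound 1

The source may hold more compounds than are shown below. What is called first, only, known or untested is meant among the compounds shown, and "the series" means these compounds.

In a functional assay on MCF7 cells (Homo sapiens) for antiproliferative activity (on this read-out lower numbers stand for stronger inhibition and higher numbers for weaker inhibition), compound 1 `N#CN/C(=N\CCCCCCOc1ccccc1)Nc1ccncc1` gives 30 nM. Among the three measured compounds it holds the second highest number. Compound 3 `N#CN/C(=N\CCCCCCOc1cccc([N+](=O)[O-])c1)Nc1ccncc1` gives 31 nM, and the step of a 1.0-fold higher number from compound 1 to compound 3 (0.01 log units; within the scatter) lies within the scatter, so the two are indistinguishable. Going by the values given here, compound 2 `N#CN/C(=N\CCCCCCOc1ccccc1Cl)Nc1ccncc1` gives 1.9 nM, and the step of a 16-fold lower number from compound 1 to compound 2 (1.20 log units; beyond the scatter) is the only large change seen in this set.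

Compound 4 `COc1ccc(OCCCCCC/N=C(\NC#N)Nc2ccncc2)cc1` differs from compound 1 by a single substituent on the aromatic ring: methoxy in place of hydrogen on an aromatic carbon. Two measured steps are comparable in kind, each placing a new group on an aromatic carbon of the same ring. The chloro step, a 16-fold lower number from compound 1 to compound 2 (1.20 log units; beyond the scatter), was large, whereas the nitro step, a 1.0-fold higher number from compound 1 to compound 3 (0.01 log units; within the scatter), stayed within the scatter. Among the compounds with values here, neither concerns a methoxy group, so no direct precedent exists. Because the step of a 1.0-fold higher number from compound 1 to compound 3 (0.01 log units; within the scatter) stayed within the scatter while the step of a 16-fold lower number from compound 1 to compound 2 (1.20 log units; beyond the scatter) was large, the expected step of a 1.2-fold lower number from compound 1 to compound 4 (0.08 log units; within the scatter) is modest, close to no change in this assay. The estimate for compound 4 is 25 nM, with a range from 8 nM to 80 nM.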

Compound 4, half-maximal inhibitory concentration: 37 nM
The estimate for compound 4 lay 1.5-fold (0.17 log units) below the measured number, within the range that was stated.
By their numbers in this assay, from the lowest: compound 2; then compounds 1, 3 and 4 (each within the scatter of the next).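

In this assay, the step of a 1.2-fold higher number from compound 1 to compound 4 (0.09 log units; within the scatter) shows that placing a methoxy group on this aromatic carbon, para to a large group, gives no change beyond the scatter, so 4-methoxyphenoxy cannot be told apart from phenoxy. Going by these compounds alone, the step of a 1.2-fold higher number from compound 3 to compound 4 (0.08 log units; within the scatter) likewise does not separate 4-methoxyphenyl from 3-nitrophenyl, whereas a 19-fold higher number from compound 2 to compound 4 (1.29 log units; beyond the scatter) confirms that compound 2, with its 2-chlorophenyl group, is the one compound set apart from all the others in this set. The data at hand offer no measurement that would explain these numbers.

From the compounds shown here alone, whether the large steps around compound 2 follow from the chloro group itself or from its place on the ring stays open, as chloro, nitro and methoxy each appear at only one place. Going by these compounds, how an amine or a carboxylic acid on this ring, or a longer chain, would read also remains open.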